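This account rests on a few compounds, and the source may have more. Where it says the series, first, only, none or still open, it means among the compounds named here.

Three compounds have been measured in a functional assay on the whole organism (artery, strain albino) with Rattus norvegicus as the target, with a stated time of 15 min, at a dose of 10 mg/kg by the oral route; on this read-out lower numbers stand for less inhibition and higher numbers for more inhibition at the one dose given (going by the name of the read-out):

Compound 1, `COc1ccc(C2N=C(SCc3ccccc3)NC(C)=C2C(=O)Nc2ccc(F)cc2)cc1OC`, gives 1.5%.
Compound 2, `COc1ccc(C2N=C(SCc3ccccc3Cl)NC(C)=C2C(=O)Nc2ccc(F)cc2)cc1OC`, gives 2.6%.
Compound 3, `COc1ccc(C2N=C(SCc3ccccc3)NC(C)=C2C(=O)Nc2ccc(Br)cc2)cc1`, gives 1%.

Compounds 1 and 2 share one core and differ in a single place: chloro in place of hydrogen on an aromatic carbon. On this assay that change made a step of a number 1.1 percentage points higher from compound 1 to compound 2 (within the scatter), a step that is within the usual scatter of repeated measurements, so the two values cannot be told apart with confidence.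

Compound 3 has a different core from compound 1, and the difference between the two cores is not broken down here. Its value sits close to those of compounds 1 and 2, and all three numbers lie within the scatter of one another, so none of the three numbers can be called higher or lower than the others.

Compound 4, `COc1ccc(C2N=C(SCc3ccccc3Cl)NC(C)=C2C(=O)Nc2ccc(Br)cc2)cc1`, has not yet been measured. It stands to compound 3 as compound 2 stands to compound 1: chloro in place of hydrogen on an aromatic carbon. The place of the change is described in the same words for both pairs, so it is the same change on a different core.

Because the earlier step was a number 1.1 percentage points higher from compound 1 to compound 2 (within the scatter), the expectation is that the same change on compound 3 gives a similarly small step, estimated as a number 1 percentage points higher from compound 3 to compound 4 (within the scatter). Compound 4 is therefore expected to give about 2% in this assay, with the estimate most likely falling between 0% and 8%.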

Compound 4, a percentage reported as inhibition, in the whole organism at one dose (the size of the read-out at that dose, not a potency): 3.1%
The estimate for compound 4 lay 1.1 percentage points below the measured number; the range from low to high includes it.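

In this assay, turning the benzyl group into 2-chlorobenzyl on the second core gives a number 2.1 percentage points higher from compound 3 to compound 4 (within the scatter). Set beside the same change on the first core, this step cannot be told apart from the earlier one: the same change on two cores in this assay, a number 1.1 percentage points higher (within the scatter) from compound 1 to compound 2 and a number 2.1 percentage points higher (within the scatter) from compound 3 to compound 4, 1 percentage points apart, within the scatter of two such steps. The two cores therefore give no sign that the change behaves differently from one to the other, but this is weak support for carrying it across the series: each step lies within the scatter, so neither core shows that the chloro group changes the read-out at all, and agreement between two steps of this kind does not show a shared effect.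

The compounds shown hold only hydrogen or chloro at this place on the ring, all with the benzylsulfanyl framework, so it remains open what an amine or a carboxylic acid there would give in this assay. Going by these compounds, it is also open whether a longer chain in place of the benzyl group would give a step that stands clear of the scatter, which is what a firm comparison between cores would need.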